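The compounds below may be only part of what the source reports. "The series", "measured", "known", "first", "only" and "open" are said of these compounds alone.

Compound 1 `CCCNC(=O)Nc1nc2ccc(-c3cnc(OC)c(NS(=O)(=O)c4ccc(F)cc4)c3)cn2n1` gives 360 nM in a functional assay on MCF7 cells (Homo sapiens) for cytotoxicity, read by MTT assay, with a stated time of 72 h (on this read-out higher numbers stand for weaker inhibition and lower numbers for stronger inhibition), the smaller of the two numbers recorded so far, though not by a margin that means anything. Within the data shown here, its only measured companion is compound 2 `COc1ncc(-c2ccc3nc(NC(=O)NCCN4CCCC4)nn3c2)cc1NS(=O)(=O)c1ccc(F)cc1`, which gives 380 nM in this assay; the step of a 1.1-fold higher number from compound 1 to compound 2 (0.02 log units; within the scatter) leaves the two within the scatter of each other. Compound 3 `CNC(=O)Nc1nc2ccc(-c3cnc(OC)c(NS(=O)(=O)c4ccc(F)cc4)c3)cn2n1` has not yet been measured. It differs from compound 1 by a (hydrogen in place of ethyl on a saturated chain carbon bound to an amide-type nitrogen). Among the measured compounds shown here, the one measured step, from compound 1 to compound 2, altered the same side chain, but at a saturated chain carbon two bonds along the chain from an amide-type nitrogen, and produced nothing beyond the scatter, so it speaks only indirectly to the shortening made here. For the measured compounds named here, with no measured step pointing in either direction, the expectation for compound 3 in this assay is a step no larger than the scatter, a 1.3-fold higher number from compound 1 to compound 3 (0.10 log units; within the scatter). Compound 3 is therefore estimated at 450 nM, with a likely range from 200 nM to 1000 nM.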

Compound 3, half-maximal inhibitory concentration: 250 nM
Beside the measured number, compound 3's estimate is 1.8-fold (0.26 log units) above it; the measured number falls inside the stated range.
By their numbers in this assay, from the lowest: compounds 3, 1 and 2 (each within the scatter of the next).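

In this assay, shortening the side chain from propyl to methyl gives a 1.4-fold lower number from compound 1 to compound 3 (0.16 log units; within the scatter), so removing this ethyl from a saturated chain carbon bound to an amide-type nitrogen moves the number no further than repeated measurements of one compound might. Replacing the larger (pyrrolidin-1-yl)methyl with hydrogen at the same place gives a 1.5-fold lower number from compound 2 to compound 3 (0.18 log units; within the scatter), so the three compounds cannot be put in order, and the methyl, propyl and pyrrolidine-bearing chains all give values that this read-out does not tell apart. No independent measurement is available that could explain these numbers.

The compounds shown leave open whether this insensitivity extends to quite different groups at the end of the chain, such as a carboxylic acid, a phenyl ring or a much longer chain like octyl. They also leave open what happens if the whole methylcarbamoyl is replaced by something else, for example a simple primary amine on the shared core, and whether the same flat picture would appear beyond this assay in other cells.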